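This account rests on a few compounds, and the source may have more. Where it says the series, first, only, none or still open, it means among the compounds named here.

Compound 3 `CN(C)c1nc(Br)nc2c1ncn2[C@@H]1C[C@@H](O)[C@H](CO)O1` sits in a functional assay on Raji cells (Homo sapiens) (on this read-out lower numbers stand for stronger inhibition and higher numbers for weaker inhibition), at > 300 uM, which is a limit of the assay and not a number. Compound 2 `CNc1nc(SC)nc2c1ncn2[C@@H]1C[C@@H](O)[C@H](CO)O1` likewise reaches only the limit > 300 uM in this assay. Compound 1 `CSc1nc(SC)c2ncn([C@@H]3C[C@@H](O)[C@H](CO)O3)c2n1` gives 170 uM in this assay. Among the compounds with values here, the single measured step, an at least 1.7-fold higher number from compound 1 to compound 2 (0.24 log units; that floor lies within the scatter), has a floor within the scatter, and the limit of > 300 uM in this assay, at which 2 of the 3 values shown sit, shows how close the series sits to the edge of the assay. Compound 4 `CSc1nc(N(C)C)c2ncn([C@@H]3C[C@@H](O)[C@H](CO)O3)c2n1` differs from compound 3 by methylsulfanyl in place of bromo on an aromatic carbon. Within the data shown here, no measured step covers this change; the dimethylamino of compound 3 and the methylsulfanyl of compound 1 both belong to compounds at or near the limit, so no step beyond the scatter is expected. Compound 4 is therefore estimated at 300 uM (range 120 uM to 800 uM), meaning a number no higher from compound 3 to compound 4 (the limit leaves the size open), most likely again reported as a limit.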

Compound 4, concentration for 50% inhibition: 233 uM
For compound 4 the middle estimate is 1.3-fold (0.11 log units) above the measured one; the measured number falls inside the stated range.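

Within the data shown here, compound 4 gives the first measured number in this assay for a compound carrying dimethylamino, yet methylsulfanyl in place of bromo on the carbon between two ring nitrogen atoms gives only an at least 1.2-fold lower number from compound 3 to compound 4 (0.10 log units; that floor lies within the scatter). Methyl in place of hydrogen on the amino nitrogen gives an at least 1.2-fold lower number from compound 2 to compound 4 (0.10 log units; that floor lies within the scatter), and dimethylamino in place of methylsulfanyl gives a 1.4-fold higher number from compound 1 to compound 4 (0.14 log units; within the scatter), so none of these changes separates the compounds beyond the scatter. The series stays at the edge of the read-out: the limit of > 300 uM in this assay, at which 2 of the 4 values shown sit.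

On these data alone, whether a carboxylic acid or a longer alkyl chain on that carbon would move the number beyond the scatter remains open.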